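The compounds below may be only part of what the source reports. "The series", "measured", "known", "first", "only" and "open" are said of these compounds alone.

Compound 1 `CC(C)[C@H](NC(=O)COc1cccc2ccccc12)C(=O)N[C@@H](CC(=O)O)C(=O)CSc1nc2ccccc2[nH]1`: in a functional assay on Jurkat cells (Homo sapiens) for inhibition (on this read-out lower numbers stand for stronger inhibition and higher numbers for weaker inhibition), compound 1 gives > 200000 nM, which is a limit of the assay.
Compound 2 `Cc1cc(OCC(=O)[C@H](CC(=O)O)NC(=O)[C@@H](NC(=O)COc2cccc3ccccc23)C(C)C)nc(C)n1`: in this assay compound 2 gives > 200000 nM, again a limit.
Compound 3 `Cc1cc(C)nc(SCC(=O)[C@H](CC(=O)O)NC(=O)[C@@H](NC(=O)COc2cccc3ccccc23)C(C)C)n1`: in this assay compound 3 gives > 200000 nM, once more a limit.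

Compound 3 therefore stands at the same limit as every other value shown, (the limit of > 200000 nM in this assay, at which 3 of the 3 values shown sit). The changes measured around it, a step that the two limits leave unreadable from compound 1 to compound 3 and a step that the two limits leave unreadable from compound 2 to compound 3, are unreadable in size for that reason, as is a step that the two limits leave unreadable from compound 1 to compound 2.

Compound 4 `CC(C)[C@H](NC(=O)COc1cccc2ccccc12)C(=O)N[C@@H](CC(=O)O)C(=O)COc1nccc2ccccc12` carries a different group at the same place: (isoquinolin-1-yl)oxy in place of (4,6-dimethylpyrimidin-2-yl)sulfanyl on a saturated chain carbon bound to a carbonyl carbon. For the measured compounds named here, no measured step offers a readable size for this kind of change, so nothing supports an expectation of movement beyond the scatter. Compound 4 is expected to give 150000 nM, within 30000 nM to 300000 nM, most likely again reported only as a limit. The estimated step of an at least 1.3-fold lower number from compound 3 to compound 4 (0.12 log units; that floor lies within the scatter) is accordingly expected to be small.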

Compound 4, half-maximal inhibitory concentration: 106000 nM
Compound 4: middle estimate off by 1.4-fold (0.15 log units), on the high side, and the stated range covers the measured number.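

Compound 4 is the only compound shown in this assay that gives a number rather than a limit, so a change on the saturated chain carbon bound to a carbonyl carbon now registers as a reading. On these data alone, the comparisons show an at least 1.8-fold lower number from compound 3 to compound 4 (0.27 log units; that floor lies within the scatter), an at least 1.8-fold lower number from compound 2 to compound 4 (0.27 log units; that floor lies within the scatter) and an at least 1.8-fold lower number from compound 1 to compound 4 (0.27 log units; that floor lies within the scatter); these are floors, and their true sizes remain unknown. The steps among compound 1, compound 2 and compound 3 still cannot be read because their values share one limit: the limit of > 200000 nM in this assay, at which 3 of the 4 values shown sit.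

As far as these compounds go, it remains open whether isoquinolin-1-yl on a sulfur would read the same. From the compounds shown here alone, it is also open whether a phenoxy group or an amine at this place would move the number beyond the scatter.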